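This account rests on a few compounds, and the source may have more. Where it says the series, first, only, none or still open, it means among the compounds named here.

Measured so far in an ADME assay on WI-38 cells (Homo sapiens) for cytotoxicity, read by MTT assay, with a stated time of 72 h (a higher number here means a weaker inhibitor, a lower number a stronger inhibitor), on the shared core
compound 1 `O=C(CCc1cccc2c1B(O)OC2)Nc1ccccc1` gives 30000 nM
compound 2 `COc1ccccc1NC(=O)CCc1cccc2c1B(O)OC2` gives 1600 nM
compound 3 `O=C(CCc1cccc2c1B(O)OC2)Nc1cccc2ccccc12` gives 1200 nM

On these numbers compound 2 stands within the scatter of compound 3 and far from compound 1. Still unmeasured is compound 4 `O=C(CCc1cccc2c1B(O)OC2)Nc1ccccc1-c1ccccc1` with this change from compound 2: phenyl in place of methoxy on an aromatic carbon that is, phenyl in place of methoxy on an aromatic carbon, ortho to a large group.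

Within the data shown here, the one measured step bearing on this is a 19-fold lower number from compound 1 to compound 2 (1.27 log units; beyond the scatter) and it is large, with methoxy in place of hydrogen on an aromatic carbon. Among the measured compounds shown here, no measured step replaces methoxy itself, so its bearing is indirect. Compound 3 at 1200 nM also sits far from compound 1 without a methoxy group. Compound 4 keeps a group on the same carbon, so the large drop is expected to persist, and no step beyond the scatter is expected in this assay for this swap. The estimated step is a 1.1-fold lower number from compound 2 to compound 4 (0.03 log units; within the scatter) with either direction possible. For compound 4 the estimated value is 1500 nM with an expected range of 500 nM to 6000 nM in this series.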

Compound 4, half-maximal inhibitory concentration: 77000 nM
For compound 4 the middle estimate is 51-fold (1.71 log units) below the measured one; measured number outside the range, above it.
By their numbers in this assay, from the lowest: compounds 3 and 2 (each within the scatter of the next); then compound 1; then compound 4.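

In this assay this position proves sensitive to which group it carries: phenyl in place of methoxy on the aromatic carbon, ortho to a large group, gives a 48-fold higher number from compound 2 to compound 4 (1.68 log units; beyond the scatter) and removes the whole of the drop seen with methoxy. Having a group on this carbon is therefore not enough for a low number, as phenyl in place of hydrogen gives a 2.6-fold higher number from compound 1 to compound 4 (0.41 log units; beyond the scatter) and moves the number in the opposite direction from methoxy in place of hydrogen. Nothing available here explains this reversal.

With only hydrogen, methoxy and phenyl shown on this carbon, it remains open whether the low number belongs to methoxy alone or extends to other groups. Ethoxy, fluorine or an amine on the same carbon would help to separate those two readings.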